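The compounds below may be only part of what the source reports. "The series", "measured", "known", "first", "only" and "open" are said of these compounds alone.

In a functional assay on K562 cells (Homo sapiens) for cytotoxicity, read by MTT assay, with a stated time of 3 days (on this read-out higher numbers stand for weaker inhibition and lower numbers for stronger inhibition), three compounds sharing one core have been measured. Compound 1 `N#Cc1c(O)nc(SCc2nc3ccccc3[nH]2)nc1-c1ccccc1` gives 4.63 nM, compound 2 `N#Cc1c(Nc2ccccc2)nc(SCc2nc3ccccc3[nH]2)nc1-c1ccccc1` gives 3.2 nM, and compound 3 `CCNc1nc(SCc2nc3ccccc3[nH]2)nc(-c2ccccc2)c1C#N` gives 4.38 nM. These values lie within the usual scatter of one another, so compound 2 does not stand apart. Compound 4 `N#Cc1c(Nc2ccccn2)nc(SCc2nc3ccccc3[nH]2)nc1-c1ccccc1` differs from compound 2 in one place: pyridin-2-yl in place of phenyl on a nitrogen on an aromatic ring. In words, this is pyridin-2-yl in place of phenyl on a nitrogen on an aromatic ring. The closest evidence is a 1.4-fold higher number from compound 2 to compound 3 (0.14 log units; within the scatter), which swaps phenyl for ethyl on that nitrogen. The steps of a 1.4-fold lower number from compound 1 to compound 2 (0.16 log units; within the scatter) and a 1.1-fold lower number from compound 1 to compound 3 (0.02 log units; within the scatter) are similarly small. Within the data shown here, no measured compound carries pyridin-2-yl, so a change beyond the scatter is not expected in this assay. The expected change is a 1.1-fold higher number from compound 2 to compound 4 (0.04 log units; within the scatter). Compound 4 is estimated at 3.5 nM, with an expected range of 1.5 nM to 8 nM.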

Compound 4, half-maximal inhibitory concentration: 7 nM
Estimate against measurement, compound 4: 2.0-fold (0.30 log units) below; the measured number falls inside the stated range.
By their numbers in this assay, from the lowest: compounds 2, 3, 1 and 4 (each within the scatter of the next, the first and the last beyond it).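

Pyridin-2-yl in place of phenyl on this nitrogen gives the only step in this set beyond the scatter, a 2.2-fold higher number from compound 2 to compound 4 (0.34 log units; beyond the scatter) and a modest one. The other two comparisons stay within the scatter, with a 1.6-fold higher number from compound 3 to compound 4 (0.20 log units; within the scatter) and a 1.5-fold higher number from compound 1 to compound 4 (0.18 log units; within the scatter) so the new group separates only from the anilino group of compound 2. No measured evidence here accounts for this shift.

The compounds shown leave open how pyridin-3-yl, pyridin-4-yl or a longer chain such as butyl on this nitrogen would compare.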